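A few compounds are considered here, and "the series" means these few. Any claim that something is new, unique, unknown or untested is made for them only; others in the source may bear on it.

Values in a functional assay on HepG2 cells (Homo sapiens) for cytotoxicity, read by MTT assay; on this read-out lower numbers stand for stronger inhibition and higher numbers for weaker inhibition:
- compound 1 `COc1ccc(/C=C/C(=O)c2ccc(OC)c3c2OC(C)(C)C=C3)cc1O`: 450 nM
- compound 2 `COc1ccc(/C=C/C(=O)c2ccc(OC)c3c2OC(C)(C)C=C3)cc1OCC=C(C)C`: > 10000 nM (a limit)
- compound 3 `C=CCOc1cc(/C=C/C(=O)c2ccc(OC)c3c2OC(C)(C)C=C3)ccc1OC`: > 10000 nM (a limit)

Compound 3 stands at > 10000 nM, which is a limit of this assay and not a number. Compound 2 also gives only a limit, and the limit of > 10000 nM in this assay, at which 2 of the 3 values shown sit, shows how much of this small set rests on that limit.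

Compound 4 `COc1ccc(/C=C/C(=O)c2ccc(OC)c3c2OC(C)(C)C=C3)cc1OCCO` differs from compound 3 as follows: hydroxymethyl in place of vinyl on a saturated chain carbon bound to an oxygen on an aromatic ring. In words, hydroxymethyl takes the place of vinyl on a saturated chain carbon bound to an oxygen on an aromatic ring, which also reads as allyl to 2-hydroxyethyl.

The closest guidance comes from replacing the hydrogen on that oxygen. The allyl group gave an at least 22-fold higher number from compound 1 to compound 3 (1.34 log units; beyond the scatter), and 3-methylbut-2-en-1-yl gave an at least 22-fold higher number from compound 1 to compound 2 (1.34 log units; beyond the scatter). Both are large steps towards weaker inhibition. Comparing those two groups gives a step that the two limits leave unreadable from compound 2 to compound 3, so the data cannot rank them.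

Compound 4 also carries a group in place of that hydrogen, so it should sit nearer compound 3 than compound 1. Its new hydroxyl leaves room for a modest move to a lower number, and a result at the limit remains quite possible. The expected step is an at least 1.6-fold lower number from compound 3 to compound 4 (0.22 log units; that floor lies within the scatter), and this is only a rough estimate.

For compound 4 the estimated value is 6000 nM, with an expected range from 1500 nM to 20000 nM.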

Compound 4, half-maximal inhibitory concentration: > 10000 nM
Compound 4 was reported as a limit; the forecaster's own chance of this, stated with the estimate: 45%; at least 1.6-fold (0.22 log units) between middle value and limit.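

In this assay, 2-hydroxyethyl in place of the hydrogen on the oxygen gives an at least 22-fold higher number from compound 1 to compound 4 (1.34 log units; beyond the scatter), so a chain ending in a hydroxyl joins allyl and 3-methylbut-2-en-1-yl in this large step towards weaker inhibition, and the hydroxyl at the chain end does not bring back the value of compound 1. Compound 4 gives > 10000 nM, which is a limit and not a number. The steps from compound 2 and from compound 3 to compound 4 cannot be read, so the three chains cannot be ranked against each other, because so many values rest on one limit: the limit of > 10000 nM in this assay, at which 3 of the 4 values shown sit.

What stays open is whether any group on this oxygen can keep a value close to that of compound 1, at 450 nM, since a plain methyl, the smallest such group, and a chain ending in an amine or a carboxylic acid are not among the compounds shown. On these data alone, how far compound 2, compound 3 and compound 4 really lie from one another also stays unknown.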